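The source may report more compounds than this note shows. Statements on the series, on what has been measured and on what is new or still open speak of the compounds shown alone.

Compound 1 `CCS(=O)(=O)Nc1cc(C2CCCCC2)cc2c1CCCC2c1c[nH]cn1` is one of a small set of imidazole-bearing fused bicyclic sulfonamides examined in an assay on isolated protein for binding affinity to Alpha-1D adrenergic receptor (Rattus norvegicus), read by radioligand binding; a higher number here means a weaker inhibitor, a lower number a stronger inhibitor. In this assay compound 1 gives 447 nM, the lowest of the two numbers in hand. Compound 2 `CS(=O)(=O)Nc1cccc2c1CCCCC2c1c[nH]cn1`, which carries a methylsulfonyl group and a seven-membered saturated ring in the core and lacks the cyclohexyl group, gives 2510 nM in this assay, a value that lies beyond the scatter above that of compound 1. Compound 3 `CCS(=O)(=O)Nc1cccc(Sc2c[nH]cn2)c1` is an open, non-fused analogue with a sulfur bridge to the imidazole; for compound 3 this assay reports only a limit, < 10000 nM, consistent with the limit of < 10000 nM in this assay, at which 1 of the 3 values shown sits.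

Compound 4 `CCS(=O)(=O)Nc1cc(Cl)cc2c1CCCC2c1c[nH]cn1` is not yet measured in this assay. It differs from compound 1 by chloro in place of cyclohexyl on an aromatic carbon. For the measured compounds named here, since the only cyclohexyl-bearing compound is also the one with the lowest number, the change is expected to cost affinity, with a moderate step estimated as a 3.4-fold higher number from compound 1 to compound 4 (0.53 log units; beyond the scatter). Compound 4 is therefore estimated to give about 1500 nM in this assay, with a likely range from 400 nM to 6000 nM.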

Compound 4, inhibition constant: 363 nM
The estimate for compound 4 lay 4.1-fold (0.62 log units) above the measured number; measured number outside the range, below it.
By their numbers in this assay, from the lowest: compounds 4 and 1 (each within the scatter of the next); then compound 2.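

In this assay, the change on this aromatic carbon, meta to the (ethylsulfonyl)amino group, gives a 1.2-fold lower number from compound 1 to compound 4 (0.09 log units; within the scatter), a step within the scatter. The earlier compounds shown here could not separate the cyclohexyl group from the rest of compound 1, since no other compound differed from it in one place only. This pair shows that, on this core, the number seen for compound 1 does not depend on the cyclohexyl group, as the much smaller chloro serves equally well here.

The compounds shown leave open whether a methoxy group, an amine or a carboxylic acid at this position would also hold the number, or whether a plain hydrogen would do the same. Nothing measured among the compounds shown explains this result.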